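A few compounds are considered here, and "the series" means these few. Any claim that something is new, unique, unknown or untested is made for them only; others in the source may bear on it.

In a functional assay on MCF7 cells (Homo sapiens) for antiproliferative activity, read by MTT assay, with a stated time of 48 h (a higher number here means a weaker inhibitor, a lower number a stronger inhibitor), compound 1 (`O=C(/C=C/c1ccc(Br)cc1)Nc1cc(-c2ccc(Br)cc2)[nH]n1`) gives 920 nM and compound 2 (`Cc1ccc(-c2cc(NC(=O)/C=C/c3ccc(C(F)(F)F)cc3)n[nH]2)cc1`) gives 720 nM while compound 3 (`O=C(/C=C/c1ccc([N+](=O)[O-])cc1)Nc1cc(-c2ccccc2)[nH]n1`) gives 630 nM and stands within the scatter of both, so the three cannot be ranked. Compound 4 (`Cc1ccc(/C=C/C(=O)Nc2cc(-c3ccccc3)[nH]n2)cc1`) differs from compound 3 by having methyl in place of nitro on an aromatic carbon, para to a large group (methyl in place of nitro on an aromatic carbon). Among the measured compounds shown here, no measured pair differs in one place only, so the data hold no direct step for this change. With compound 1 at 920 nM and compound 2 at 720 nM both within the scatter of compound 3 at 630 nM and carrying other substituents, no step beyond the scatter is expected in this assay in either direction. For compound 4 the estimated value is 800 nM with an expected range of 320 nM to 2000 nM.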

Compound 4, half-maximal inhibitory concentration: 1780 nM
Beside the measured number, compound 4's estimate is 2.2-fold (0.35 log units) below it; the range from low to high includes it.
By their numbers in this assay, from the lowest: compounds 3, 2, 1 and 4 (each within the scatter of the next, the first and the last beyond it).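

In this assay, methyl in place of nitro on an aromatic carbon, para to a large group, gives a 2.8-fold higher number from compound 3 to compound 4 (0.45 log units; beyond the scatter) and so shows that the group at this position can move the number beyond the scatter. The earlier compounds shown here could not show this, since compound 3 stood within the scatter of compound 1 and compound 2, which differ from it in more than one place. Nothing available accounts for this step.

Going by these compounds, whether an amine, a methoxy group or a carboxylic acid at this position would fall nearer compound 3 or compound 4 remains open. So does whether the same change would give a similar step with the other substituents of compound 1 or compound 2.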